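A Halogen Swap Tested Again on a Second Core

A few compounds are considered here, and "the series" means these few. Any claim that something is new, unique, unknown or untested is made for them only; others in the source may bear on it.

Compound 1 `COc1cccc(Cc2cc(-c3ccccc3)nn(CC(=O)Nc3ccc(Br)cc3)c2=O)c1` and compound 2 `COc1cccc(Cc2cc(-c3ccccc3)nn(CC(=O)Nc3ccc(F)cc3)c2=O)c1` share one core and differ in a single place, (fluoro in place of bromo on an aromatic carbon). In a functional assay on HL-60 cells (Homo sapiens), read by calcium flux (a higher number here means that more compound is needed for the effect, a lower number that less compound is needed), compound 1 gives only a limit, > 50000 nM. Compound 2 likewise gives only a limit in this assay, > 50000 nM. The step that the two limits leave unreadable from compound 1 to compound 2 therefore cannot be sized. Compound 3 `Cc1cc(Cc2ccccc2)c(=O)n(CC(=O)Nc2ccc(Br)cc2)n1` rests on a different core; the difference between the two cores is not broken down here. In this assay compound 3 also gives only a limit, > 50000 nM. Among the compounds with values here, all three values so far sit together, (the limit of > 50000 nM in this assay, at which 3 of the 3 values shown sit). Compound 4 `Cc1cc(Cc2ccccc2)c(=O)n(CC(=O)Nc2ccc(F)cc2)n1` is not yet measured; it differs from compound 3 by the same change, (fluoro in place of bromo on an aromatic carbon), made at a place described in the same words. Compound 1 and compound 2 both stand at that limit, (the limit of > 50000 nM in this assay, at which 3 of the 3 values shown sit), and compound 3 stands there as well, so compound 4 is expected to remain there, an estimated step that the limit leaves unreadable from compound 3 to compound 4. Compound 4 is estimated at 80000 nM in this assay, between 30000 nM and 300000 nM, most likely reported only as a limit.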

Compound 4, half-maximal effective concentration: > 50000 nM
Compound 4 was reported as a limit; the forecaster's own chance of this, stated with the estimate: 85%; the middle value lies beyond the limit too.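

Within the data shown here, compound 3 and compound 4 are both reported only as limits in this assay, so no step between them can be read, and the same holds for compound 1 and compound 2: the limit of > 50000 nM in this assay, at which 4 of the 4 values shown sit. The compounds shown leave open whether fluoro in place of bromo changes the response on either core, since none gives a reading inside the limit.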